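The compounds below may be only part of what the source reports. "The series", "measured", "known", "first", "only" and "open" are said of these compounds alone.

Compound 3 `CN(C)CCn1cnnc1-c1cc(Oc2ccc(NC(=O)N/N=C/c3cccc(Cl)c3Cl)cc2F)ccn1` stands alone with a number: in an ADME assay on WI-38 cells (Homo sapiens) for cytotoxicity, read by MTT assay, with a stated time of 72 h (a higher number here means a weaker inhibitor, a lower number a stronger inhibitor), compound 3 gives 6130 nM. Its two companions, compound 1 `CN(C)CCn1cnnc1-c1cc(Oc2ccc(NC(=O)N/N=C/c3ccccc3)cc2F)ccn1` and compound 2 `CN(C)CCn1cnnc1-c1cc(Oc2ccc(NC(=O)N/N=C/c3ccc(O)c(O)c3)cc2F)ccn1`, share the same core and differ only in the aryl group on the carbon with a double bond to nitrogen. In this assay compound 1 gives "not determined" (no result reported), and in this assay compound 2 gives "not determined" (no result reported). So there is no second number to set beside compound 3 and no step between measured compounds to draw on.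

Compound 4 `CN(C)CCn1cnnc1-c1cc(Oc2ccc(NC(=O)N/N=C/c3ccc(F)cc3Cl)cc2F)ccn1` is the next member of this set, and the change from compound 3 to compound 4 is a small one at the same position: 2-chloro-4-fluorophenyl in place of 2,3-dichlorophenyl on a carbon with a double bond to nitrogen. Within the data shown here, with no measured step of this kind to lean on, the expectation rests on the size of the change alone, and nothing in it suggests a move beyond the usual scatter in either direction. The step from compound 3 to compound 4 is therefore expected to be a 1.1-fold higher number from compound 3 to compound 4 (0.06 log units; within the scatter). Compound 4 is estimated at 7000 nM, with a range from 3000 nM to 16000 nM.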

Compound 4, half-maximal inhibitory concentration: 2090 nM
The estimate for compound 4 lay 3.3-fold (0.52 log units) above the measured number; the whole stated range lies above it.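

In this assay, among these compounds, the aryl group on the carbon with a double bond to nitrogen proves able to move the reading: 2-chloro-4-fluorophenyl in place of 2,3-dichlorophenyl gives a 2.9-fold lower number from compound 3 to compound 4 (0.47 log units; beyond the scatter), a step beyond the scatter and the only change at this position that can be read. The two groups match in heavy-atom count and carry no hydrogen-bond donors, no hydrogen-bond acceptors and no net charge, so a swap that leaves all of these unchanged is still enough to shift the number. Nothing at hand explains the step.

The steps to compound 1 and compound 2 cannot be read: neither has a number. Also open, going by these compounds, is how the reading would respond to an aryl group carrying an amine or a carboxylic acid at this position.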